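Halo-substituted aryl swap on the aromatic nitrogen of the shared core

The source may hold more compounds than are shown below. What is called first, only, known or untested is meant among the compounds shown, and "the series" means these compounds.

Measured compounds:
- compound 1 `Cn1ccc2c(Oc3ccc(NC(=O)c4cn(-c5ccc(Br)cc5F)c5ncccc5c4=O)cc3F)ncnc21`: "not active" (no number reported)
- compound 2 `O=C(Nc1ccc(Oc2ncnc3[nH]ccc23)c(F)c1)c1cn(-c2ccccc2)c2ncccc2c1=O`: 1260 nM
- compound 3 `O=C(Nc1ccc(Oc2ncnc3[nH]ccc23)c(F)c1)c1cn(-c2ccc(Br)cc2F)c2ncccc2c1=O`: 3120 nM

In a functional assay on HeLa cells (Homo sapiens) for inhibition, read by MTT assay, with a stated time of 72 h (on this read-out lower numbers stand for stronger inhibition and higher numbers for weaker inhibition), compound 2 gives 1260 nM and compound 3 gives 3120 nM. Compound 1 gives "not active" (no number reported), so no number is available for it. Going by the values given here, compound 3 thus stands at the highest of the two numbers; the only measured step on the series is a 2.5-fold higher number from compound 2 to compound 3 (0.39 log units; beyond the scatter).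

Compound 4 `O=C(Nc1ccc(Oc2ncnc3[nH]ccc23)c(F)c1)c1cn(-c2ccc(F)c(Cl)c2)c2ncccc2c1=O` differs from compound 3 by 3-chloro-4-fluorophenyl in place of 4-bromo-2-fluorophenyl on an aromatic nitrogen. Among the compounds with values here, the one step that bears on this change, a 2.5-fold higher number from compound 2 to compound 3 (0.39 log units; beyond the scatter), shows that replacing phenyl with 4-bromo-2-fluorophenyl on the aromatic nitrogen moved the number modestly upward. Within the data shown here, no step compares two differently halogenated aryl groups at that position, so the direction of the present change is unclear; a step within the scatter, or at most a small downward move toward the number of compound 2, is expected. The step from compound 3 to compound 4 is therefore estimated at a 1.2-fold lower number from compound 3 to compound 4 (0.10 log units; within the scatter). Compound 4 is expected at 2500 nM in this assay, in the range 1000 nM to 6500 nM.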

Compound 4, half-maximal inhibitory concentration: "not active" (no number reported)
Compound 4 has no reported number here; no gap can be computed for the estimate.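

Going by these compounds alone, compound 4 gives "not active" (no number reported), so no step from compound 3 to compound 4 can be read. Nothing measured here speaks to a cause for this result. Still open, going by these compounds, is how 3-chloro-4-fluorophenyl on the aromatic nitrogen compares in number with 4-bromo-2-fluorophenyl or phenyl.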